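Amide side-chain exchange and cytotoxicity within the series

This account rests on a few compounds, and the source may have more. Where it says the series, first, only, none or still open, it means among the compounds named here.

Compound 1 `CCCc1cc(CNC(=O)c2cc3nc(C)c([C@H](OC(C)(C)C)C(=O)O)c(-c4cc(F)c5c(c4C)CCCO5)n3n2)ccc1F` carries on the shared core an amide whose nitrogen bears 4-fluoro-3-propylbenzyl. Among the measured compounds shown here, in an ADME assay on MT2 cells (Homo sapiens) for cytotoxicity (on this read-out higher numbers stand for lower toxicity in this test and lower numbers for higher toxicity in this test), compound 1 gives > 20000 nM, which is a limit of the test and not a number, so compound 1 cannot be placed on a scale; the one other value known is a limit too. Compound 2 `Cc1nc2cc(C(=O)NCCC(C)(C)C)nn2c(-c2cc(F)c3c(c2C)CCCO3)c1[C@H](OC(C)(C)C)C(=O)O` carries neopentyl in place of 4-fluoro-3-propylphenyl on a saturated chain carbon bound to an amide-type nitrogen. In this assay compound 2 gives > 40000 nM, again a limit. The step that the two limits leave unreadable from compound 1 to compound 2 is unreadable in size, since both ends sit at limits, as the limit of > 20000 nM in this assay, at which 1 of the 2 values shown sits, and the limit of > 40000 nM in this assay, at which 1 of the 2 values shown sits, show.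

Compound 3 `Cc1nc2cc(C(=O)NCCC3CCOCC3)nn2c(-c2cc(F)c3c(c2C)CCCO3)c1[C@H](OC(C)(C)C)C(=O)O` is the unmeasured analogue. It differs from compound 1 in one place: (oxan-4-yl)methyl in place of 4-fluoro-3-propylphenyl on a saturated chain carbon bound to an amide-type nitrogen. For the measured compounds named here, the only measured step exchanges the same group at the same place, and its size is unreadable. No readable step bears on the change, so no shift beyond the scatter is expected in this assay; compound 3 is expected to sit at a limit as well. The estimate for compound 3 in this assay is 40000 nM, between 15000 nM and 100000 nM, meaning an expected step that the limit leaves unreadable from compound 1 to compound 3.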

Compound 3, half-maximal cytotoxic concentration: > 40000 nM
Compound 3 was reported as a limit; the forecaster's own chance of this, stated with the estimate: 85%; the middle value lies on the limit itself.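

In this assay compound 3 gives > 40000 nM, a limit of the test and not a number. Among the compounds shown here, no step from compound 1 or compound 2 to compound 3 can be read, as all three values are limits. The compounds shown leave open whether these amide side chains differ at all in this assay.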